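The source may report more compounds than this note shows. Statements on the series, on what has been measured and on what is new or still open speak of the compounds shown alone.

Measured so far:
Compound 1, `C=CCn1c(=O)/c(=C\c2cccc(C)c2)[nH]c(=O)/c1=C\c1ccccc1OC`, gives 16700 nM.
Compound 2, `COc1ccccc1/C=c1\c(=O)[nH]/c(=C/c2ccccc2Cl)c(=O)n1C`, gives 200 nM.

Both numbers come from a functional assay on HL-60 cells (Homo sapiens) for cytotoxicity, read by CCK-8 assay, with a stated time of 72 h; a higher number here means a weaker inhibitor, a lower number a stronger inhibitor. Of the two, compound 1 stands at the higher value, so it is the weaker inhibitor; compound 2 lies far lower, and the gap between the two is well beyond the usual scatter. The two compounds differ in several places at once, so this gap cannot be tied to any single change.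

Compound 3, `C=CCn1c(=O)/c(=C\c2cccc(Br)c2)[nH]c(=O)/c1=C\c1ccccc1OC`, has not yet been measured. It differs from compound 1 in a single place: bromo in place of methyl on an aromatic carbon. Going by the values given here, no measured pair shows this exact exchange, so the size of the step rests on expectation alone. The step of a 1.4-fold lower number from compound 1 to compound 3 (0.14 log units; within the scatter) is expected to be small, within the scatter, without a clear direction. Compound 3 is expected to give about 12000 nM, with a range from 4000 nM to 40000 nM.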

Compound 3, half-maximal inhibitory concentration: 5200 nM
For compound 3 the middle estimate is 2.3-fold (0.36 log units) above the measured one; the range from low to high includes it.
By their numbers in this assay, from the lowest: compound 2; then compound 3; then compound 1.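

This aromatic carbon is sensitive to what it carries: the change from 3-methylphenyl to 3-bromophenyl swaps one heavy atom for one heavy atom, with no hydrogen-bond donor or acceptor on either side, yet it gives a 3.2-fold lower number from compound 1 to compound 3 (0.51 log units; beyond the scatter) in this assay on this single pair. The step is modest, and one pair marks this position as responsive without setting up a trend among groups placed there. Nothing measured on these groups bears on the step, so the data offer no explanation for it.

As far as these compounds go, whether a nitrile or an amine on the same aromatic carbon would lower the number further or raise it stays open. So does whether the exchange of methyl for bromo moves the number by a similar amount when other parts of compound 1 are changed.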